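This account rests on a few compounds, and the source may have more. Where it says the series, first, only, none or still open, it means among the compounds named here.

Measured so far:
Compound 1 `COC(=O)c1sc2cc(C#Cc3ccsc3)cnc2c1N` gives 29600 nM in a functional assay on A375-C5 cells (Homo sapiens) for inhibition, read by sulforhodamine B assay, with a stated time of 48 h; a higher number here means a weaker inhibitor of growth, a lower number a stronger inhibitor of growth.
Compound 2 `COC(=O)c1sc2cc(C#Cc3cccc(OC)c3)cnc2c1N` gives > 75000 nM in this assay; this is a limit of the assay, not a number.

Compound 2 thus sits at the limit of > 75000 nM in this assay, at which 1 of the 2 values shown sits. Among the measured compounds shown here, the only measured step, an at least 2.5-fold higher number from compound 1 to compound 2 (0.40 log units; beyond the scatter), concerns a different exchange on the same triple-bonded carbon. Compound 3 `COC(=O)c1sc2cc(C#Cc3ccccc3N)cnc2c1N` arises through (2-aminophenyl in place of 3-methoxyphenyl on a triple-bonded carbon). For the measured compounds named here, no measured step covers this change, so the direction cannot be read from compound 1 and compound 2 alone; weak growth inhibition is expected to persist. Compound 3 is estimated at 50000 nM, between 12000 nM and 150000 nM. The expected step is an at least 1.5-fold lower number from compound 2 to compound 3 (0.17 log units; that floor lies within the scatter).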

Compound 3, concentration for 50% growth inhibition: 3100 nM
The estimate for compound 3 lay 16-fold (1.21 log units) above the measured number, and the stated range ends above it.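

The group on the triple-bonded carbon can do more than weaken growth inhibition: in this assay, 2-aminophenyl in place of 3-methoxyphenyl gives an at least 24-fold lower number from compound 2 to compound 3 (1.38 log units; beyond the scatter). Against thiophen-3-yl, where both values are numbers, the same group gives a 9.5-fold lower number from compound 1 to compound 3 (0.98 log units; beyond the scatter). Compound 2 stands at a limit of the assay, not a number, so its step is only a floor: the limit of > 75000 nM in this assay, at which 1 of the 3 values shown sits.

From the compounds shown here alone, whether the gain belongs to the amine or to the phenyl ring stays open. A plain phenyl or a 2-hydroxyphenyl group on the same carbon would separate the two.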